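The source may report more compounds than this note shows. Statements on the series, on what has been measured and on what is new or still open speak of the compounds shown alone.

Compound 3 `N#CC1=C(N)N(c2ccc(S(N)(=O)=O)cc2)C2=C(C(=O)CCC2)C1c1c(O)ccc2ccccc12` gives 0% in a functional assay on Ehrlich cells (Mus musculus) for antiproliferative activity, read by trypan blue exclusion, with a stated time of 2 h, tested at 25 ug/mL (on this read-out lower numbers stand for a weaker effect and higher numbers for a stronger effect at the one concentration tested), which puts it at the bottom of the three numbers measured, level with compound 2 `COc1ccccc1C1C(C#N)=C(N)N(c2ccc(S(N)(=O)=O)cc2)C2=C1C(=O)CCC2`, whose value is 0%, the pair differing by no change at the digits printed from compound 2 to compound 3 (within the scatter). Compound 1 `N#CC1=C(N)N(c2ccc(S(N)(=O)=O)cc2)C2=C(C(=O)CCC2)C1c1ccccc1` stands highest with 30%; the step of a number 30 percentage points lower from compound 1 to compound 3 (beyond the scatter) and the step of a number 30 percentage points lower from compound 1 to compound 2 (beyond the scatter) both fall beyond the scatter.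

Compound 4 `Cc1ccoc1C1C(C#N)=C(N)N(c2ccc(S(N)(=O)=O)cc2)C2=C1C(=O)CCC2` differs from compound 3 by 3-methylfuran-2-yl in place of 2-hydroxynaphthalen-1-yl on a saturated ring carbon. Within the data shown here, two measured steps bear on this position: the move from phenyl to 2-hydroxynaphthalen-1-yl lowered the read-out, and the move from 2-methoxyphenyl to 2-hydroxynaphthalen-1-yl left it unchanged. Only the bare phenyl has given a number clearly above zero; every other group at this carbon has given none. A 3-methylfuran-2-yl group is neither phenyl nor one of the tested aromatic groups, so the expectation is a small upward step, a number 10 percentage points higher from compound 3 to compound 4 (within the scatter), that may well stay within the scatter. Compound 4 is therefore estimated at 10%, expected to lie between 0% and 35%.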

Compound 4, a percentage reported as activity, at one concentration (the size of the read-out at that concentration, not a potency): 10%
The estimate for compound 4 equals the measured number at the digits printed; low and high end bracket the measured number.
By their numbers in this assay, from the lowest: compounds 2, 3 and 4 (each within the scatter of the next); then compound 1.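

In this assay, the five-membered 3-methylfuran-2-yl group brings a new kind of ring to this saturated ring carbon, yet the exchange gives a number 10 percentage points higher from compound 3 to compound 4 (within the scatter) and, against 2-methoxyphenyl, a number 10 percentage points higher from compound 2 to compound 4 (within the scatter) for a group with fewer heavy atoms than 2-hydroxynaphthalen-1-yl. Compound 4 therefore cannot be told apart from compound 2 or compound 3, whereas the comparison with the bare phenyl gives a number 20 percentage points lower from compound 1 to compound 4 (beyond the scatter) and leaves compound 1 alone beyond the scatter of the other three. No evidence is at hand on what sets the phenyl compound apart.

Going by these compounds, whether a cyclohexyl group or a thiophene at this carbon would sit with compound 1 or with the other three remains open. So does whether an unsubstituted furan would read as compound 4 does.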